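The source may report more compounds than this note shows. Statements on the series, on what has been measured and on what is new or still open speak of the compounds shown alone.

Measured in an ADME assay on MT4 cells (Homo sapiens) for cytotoxicity, read by MTT assay; on this read-out higher numbers stand for lower toxicity in this test and lower numbers for higher toxicity in this test:
Compound 1 `Cc1c(Cc2c(F)cccc2F)nc(SCc2ccc([N+](=O)[O-])cc2)[nH]c1=O`: > 37000 nM, a limit.
Compound 2 `Cc1c(Cc2c(F)cccc2F)nc(SCc2cccnc2)[nH]c1=O`: > 70000 nM, a limit.
Compound 3 `Cc1c(Cc2c(F)cccc2F)nc(SC(C)C)[nH]c1=O`: > 77000 nM, a limit.

Compound 2 therefore stands on a limit and not on a number, and the other two compounds do as well. Compound 4 `Cc1c(Cc2c(F)cccc2F)nc(SCC(=O)c2ccc(F)cc2)[nH]c1=O` keeps the shared core and differs from compound 2 in one place: (4-fluorophenyl)carbonyl in place of pyridin-3-yl on a saturated chain carbon bound to a sulfur. Here (4-fluorophenyl)carbonyl takes the place of pyridin-3-yl on a saturated chain carbon bound to a sulfur.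

For the measured compounds named here, two measured steps concern this same part of the molecule: a step that the two limits leave unreadable from compound 1 to compound 2 and a step that the two limits leave unreadable from compound 2 to compound 3. Neither has a readable size, so neither shows how far such a swap moves the value. Going by the values given here, with these two steps as the only guides, no step beyond the usual scatter is expected in this assay, in either direction. The expected change is an at least 1.1-fold lower number from compound 2 to compound 4 (0.06 log units; that floor lies within the scatter). Compound 4 is estimated at 60000 nM, with an expected range from 20000 nM to 100000 nM. The result may also turn out to be only a limit.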

Compound 4, half-maximal cytotoxic concentration: > 62000 nM
Compound 4: no number, only a limit; the forecaster's own chance of this, stated with the estimate: 75%; middle value at least 1.0-fold (0.01 log units) from the limit.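

Compound 4 gives only a limit, as do compounds 1, 2 and 3, so the steps from compound 1 and from compound 2 to compound 4 cannot be read. The compounds shown leave open whether these swaps change the value in this assay at all, and by how much.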